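This account rests on a few compounds, and the source may have more. Where it says the series, first, only, none or still open, it means among the compounds named here.

Measured compounds: compound 1 `Cc1ccc(-c2nc3c(N)nc(NCc4cccs4)nc3s2)o1` with 15.3 nM in an assay on CHO cells for displacement of a labelled ligand from adenosine receptor A3 (Homo sapiens), read by scintillation counting, with a stated time of 120 min; a lower number here means a stronger inhibitor, a higher number a weaker inhibitor; compound 2 `COc1ccccc1CNc1nc(N)c2nc(-c3ccc(C)o3)sc2n1` with 141 nM.

Compound 1 holds the lower of the two numbers; compound 2 lies a 9.2-fold higher number from compound 1 to compound 2 (0.96 log units; beyond the scatter) away. Compound 3 `Nc1nc(NCc2cccs2)nc2sc(-c3cccs3)nc12` differs from compound 1 by thiophen-2-yl in place of 5-methylfuran-2-yl on an aromatic carbon. Going by the values given here, the one measured step, a 9.2-fold higher number from compound 1 to compound 2 (0.96 log units; beyond the scatter), touches a different place, the saturated chain carbon bound to a nitrogen on an aromatic ring, so no measured step bears on this exchange of one five-membered aromatic ring for another. Compound 3 is therefore expected to show a step of a 1.3-fold higher number from compound 1 to compound 3 (0.12 log units; within the scatter) in this assay, not beyond the scatter. The estimate for compound 3 is 20 nM, between 6 nM and 60 nM.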

Compound 3, inhibition constant: 38 nM
The estimate for compound 3 lay 1.9-fold (0.28 log units) below the measured number; low and high end bracket the measured number.
By their numbers in this assay, from the lowest: compound 1; then compound 3; then compound 2.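

In this assay this aromatic carbon proves sensitive to its group: thiophen-2-yl in place of 5-methylfuran-2-yl gives a 2.5-fold higher number from compound 1 to compound 3 (0.40 log units; beyond the scatter) even though each group is one five-membered aromatic ring with 1 hetero atom. The shared core therefore has a second place, besides the saturated chain carbon, where an exchange moves the number beyond the scatter. The compounds shown leave open whether the ring's hetero atom or the methyl carries this step, which a plain furan-2-yl would separate, and how a phenyl ring or an amine would fare here. No available evidence accounts for the step.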